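The source may report more compounds than this note shows. Statements on the series, on what has been measured and on what is new or still open speak of the compounds shown alone.

Two pairs carry the same change, acetyl in place of hydrogen on an oxygen on a saturated carbon. Compound 2 `COc1ccc(C2=C(c3cc(OC)c(OC)c(OC)c3)C(=O)C(O)C2)cc1` in an ADME assay on ECV-304 cells (Homo sapiens) for cytotoxicity, read by MTT assay, with a stated time of 72 h (a higher number here means a weaker inhibitor, a lower number a stronger inhibitor), gives < 1 ug/mL, which is a limit of the assay (the limit of < 1 ug/mL in this assay, at which 1 of the 3 values shown sits). Compound 1 `COc1ccc(C2=C(c3cc(OC)c(OC)c(OC)c3)C(=O)C(OC(C)=O)C2)cc1` gives 18 ug/mL. The change acetyl in place of hydrogen on an oxygen on a saturated carbon therefore made an at least 18-fold higher number from compound 2 to compound 1 (1.25 log units; beyond the scatter). Compound 3 `COc1cc(C2=C(c3cc(C)c(OC)c(C)c3)C(O)CC2=O)cc(OC)c1OC` gives > 100 ug/mL, likewise a limit (the limit of > 100 ug/mL in this assay, at which 1 of the 3 values shown sits). How the core of compound 3 differs from the core of compound 2 is not broken down here. Compound 4 `COc1cc(C2=C(c3cc(C)c(OC)c(C)c3)C(OC(C)=O)CC2=O)cc(OC)c1OC` repeats the same change on compound 3, (acetyl in place of hydrogen on an oxygen on a saturated carbon), the place being the same in both pairs. Set beside the earlier step, the expected step is a step that the limit leaves unreadable from compound 3 to compound 4. This rests on compound 3 already sitting at > 100 ug/mL, so the earlier direction of the change can only keep the number at or past that limit. Compound 4 is estimated at 150 ug/mL, expected between 60 ug/mL and 500 ug/mL.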

Compound 4, half-maximal inhibitory concentration: > 100 ug/mL
Compound 4: no number, only a limit; the forecaster's own chance of this, stated with the estimate: 85%; the middle value is on the limit's open side.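

In this assay compound 4 gives > 100 ug/mL, a limit of the assay. Within the data shown here, compound 3 gives > 100 ug/mL, also a limit, so no step between compound 3 and compound 4 can be read. Still open, on these data alone, is whether hydroxy to acetoxy changes the number at all on the core of compound 3.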